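Series notes: exchanging the amine on the propyl chain

The compounds below may be only part of what the source reports. "The series", "measured", "known", "first", "only" and "open" are said of these compounds alone.

Of the compounds shown here, three with a shared core have been measured in an assay on HEK293 cells for agonist activity at Toll-like receptor 8 (Homo sapiens), read by spectrophotometry; a lower number here means that less compound is needed, a higher number that more compound is needed for the effect. Compound 1 `CCCCNc1nc(N)nc(C)c1CCCCc1ccccc1` gives 857 nM, compound 2 `CCCCNc1nc(N)nc(C)c1CCCN1CCN(C)CC1` gives 179 nM, and compound 3 `CCCCNc1nc(N)nc(C)c1CC` gives 1660 nM. Compound 2 therefore gives the lowest number of the three, with compound 3 giving the highest. For the measured compounds named here, the one counted step is a 4.8-fold lower number from compound 1 to compound 2 (0.68 log units; beyond the scatter). Compound 4 `CCCCNc1nc(N)nc(C)c1CCCN(CC)CC` is not yet measured in this assay; it differs from compound 2 as follows: diethylamino in place of 4-methylpiperazin-1-yl on a saturated chain carbon, three bonds along the chain from an aromatic carbon. Going by the values given here, no measured step exchanges one amine-bearing group for another, and the step from compound 1 to compound 2 does not cover this change. A step beyond the scatter is not expected; the estimated step is a 1.4-fold higher number from compound 2 to compound 4 (0.15 log units; within the scatter). For compound 4 the estimate in this assay is 250 nM, expected to fall between 80 nM and 800 nM.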

Compound 4, half-maximal effective concentration: 254 nM
Compound 4: the middle estimate sits 1.0-fold (0.01 log units) below what was measured; the measured number falls inside the stated range.
By their numbers in this assay, from the lowest: compounds 2 and 4 (each within the scatter of the next); then compounds 1 and 3 (each within the scatter of the next).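

Diethylamino in place of 4-methylpiperazin-1-yl gives a 1.4-fold higher number from compound 2 to compound 4 (0.15 log units; within the scatter), so at this place neither the six-membered ring nor the second ring nitrogen is required for a number in this range. Compound 4 also separates from both compounds without a chain amine, with a 6.5-fold lower number from compound 3 to compound 4 (0.82 log units; beyond the scatter) and a 3.4-fold lower number from compound 1 to compound 4 (0.53 log units; beyond the scatter). No measured evidence accounts for these steps.

Still open, going by these compounds, is whether dimethylamino, morpholine or a primary amine on the same chain would give similar numbers. Also open, on these data alone, is how a longer chain carrying diethylamino would compare.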